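Sulfonamide swap on the dichlorobenzamide: working notes

The compounds below may be only part of what the source reports. "The series", "measured", "known", "first", "only" and "open" are said of these compounds alone.

Measured in a functional assay on MCF7 cells (Homo sapiens) for antiproliferative activity; a higher number here means a weaker inhibitor, a lower number a stronger inhibitor:
- compound 1 `O=C(Nc1ccc(O)c2c(=O)cc(-c3ccccc3Cl)oc12)c1ccc(Cl)c(Cl)c1`: 15000 nM
- compound 2 `C[C@@H](NC(=O)OC(C)(C)C)C(=O)Nc1ccc(O)c2c(=O)cc(-c3ccccc3Cl)oc12`: 5500 nM

Of the two measured compounds, compound 1 holds the higher number in this assay, at 15000 nM. The unmeasured compound 3 `O=c1cc(-c2ccccc2Cl)oc2c(NS(=O)(=O)c3ccccc3)ccc(O)c12` differs from it in one place: phenylsulfonyl in place of (3,4-dichlorophenyl)carbonyl on a nitrogen on an aromatic ring. This puts phenylsulfonyl in place of (3,4-dichlorophenyl)carbonyl on a nitrogen on an aromatic ring.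

Within the data shown here, only one measured step bears on this change, and only in part: a 2.7-fold lower number from compound 1 to compound 2 (0.44 log units; beyond the scatter). That modest step also removes the 3,4-dichlorophenyl but keeps the carbonyl. Among the measured compounds shown here, no measured step replaces the carbonyl, so the direction rests on thin evidence. A similarly modest move toward a lower number is expected in this assay. The expected step is a 2.1-fold lower number from compound 1 to compound 3 (0.33 log units; beyond the scatter). For compound 3 the estimated value is 7000 nM, with an expected range of 2500 nM to 20000 nM.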

Compound 3, half-maximal inhibitory concentration: 16000 nM
Estimate against measurement, compound 3: 2.3-fold (0.36 log units) below; the range from low to high includes it.
By their numbers in this assay, from the lowest: compound 2; then compounds 1 and 3 (each within the scatter of the next).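

In this assay, a 1.1-fold higher number from compound 1 to compound 3 (0.03 log units; within the scatter), so replacing the carbonyl together with the 3,4-dichlorophenyl on this nitrogen leaves the number within the scatter. Among these compounds, the move toward a lower number in a 2.7-fold lower number from compound 1 to compound 2 (0.44 log units; beyond the scatter), which keeps the carbonyl, therefore has no counterpart in this sulfonyl exchange. Nothing available accounts for this result.

As far as these compounds go, compound 3 changes the linking carbonyl to a sulfonyl and loses both chlorine atoms in one step, so the separate contribution of each change, and whether they offset each other, stays open. Also open, from the compounds shown here alone, is how the number responds at this nitrogen to a methylsulfonyl in place of phenylsulfonyl, or to an amine or a carboxylic acid carried on the phenyl ring of the phenylsulfonyl.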